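The source may report more compounds than this note shows. Statements on the series, on what has been measured and on what is new or still open speak of the compounds shown alone.

Among the measured compounds shown here, in a functional assay on MIA PaCa-2 cells (Homo sapiens) for inhibition, read by MTT assay, with a stated time of 3 days (on this read-out higher numbers stand for weaker inhibition and lower numbers for stronger inhibition), compound 2 `CCN(CC)S(=O)(=O)c1ccc(S(=O)(=O)N2CCC[C@@H](C(=O)N3CC[C@H](OC)C3)C2)cc1` gives 460 nM, the highest of the two numbers measured so far. Compound 1 `CCN(CC)S(=O)(=O)c1ccc(S(=O)(=O)N2CCC[C@@H](C(=O)N3CCC(F)(F)CC3)C2)cc1` gives 19 nM in this assay. For the measured compounds named here, the one measured step, a 24-fold higher number from compound 1 to compound 2 (1.38 log units; beyond the scatter), shows that exchanging the group on this carbonyl carbon can move the number a great deal. Compound 3 `CCN(CC)S(=O)(=O)c1ccc(S(=O)(=O)N2CCC[C@@H](C(=O)NC3CCOCC3)C2)cc1` carries (oxan-4-yl)amino in place of 3-methoxypyrrolidin-1-yl on a carbonyl carbon. Neither measured compound has this group, so only the size of that earlier step guides the guess, and its direction is open. Compound 3 is expected to give about 600 nM in this assay, somewhere between 150 nM and 3000 nM, a step of a 1.3-fold higher number from compound 2 to compound 3 (0.12 log units; within the scatter).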

Compound 3, half-maximal inhibitory concentration: 1350 nM
Estimate against measurement, compound 3: 2.3-fold (0.35 log units) below; the range from low to high includes it.
By their numbers in this assay, from the lowest: compound 1; then compound 2; then compound 3.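

Replacing 3-methoxypyrrolidin-1-yl with (oxan-4-yl)amino keeps the same atoms but changes the ring from five-membered to six-membered and adds a hydrogen-bond donor, and even this change on the carbonyl carbon gives a 2.9-fold higher number from compound 2 to compound 3 (0.47 log units; beyond the scatter). The gap from the 4,4-difluoropiperidin-1-yl group is wider still, at a 71-fold higher number from compound 1 to compound 3 (1.85 log units; beyond the scatter), so both oxygen-containing groups give higher numbers than the difluorinated one. No measured evidence explains these differences. Ring size and the amide hydrogen change together here, so their separate contributions remain open. How a plain piperidin-1-yl group, without fluorine, would compare is also unknown.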